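This account rests on a few compounds, and the source may have more. Where it says the series, first, only, none or still open, it means among the compounds named here.

Two ribosides of the shared core have been measured in an assay on isolated protein for binding affinity to Equilibrative nucleoside transporter 1 (Homo sapiens); on this read-out lower numbers stand for stronger inhibition and higher numbers for weaker inhibition. Compound 1 `OC[C@H]1O[C@@H](n2cnc3c(SC4CCCCC4)ncnc32)[C@H](O)[C@@H]1O` gives 6310 nM in this assay. Compound 2 `Cc1cc(C)c(SCc2ncnc3c2ncn3[C@@H]2O[C@H](CO)[C@@H](O)[C@H]2O)c(C)c1` gives 33100 nM in this assay, the higher of the two numbers, with the gap to compound 1 beyond the usual scatter. Compound 3 `OC[C@H]1O[C@@H](n2cnc3c(CSc4ccccc4I)ncnc32)[C@H](O)[C@@H]1O` differs from compound 2 by 2-iodophenyl in place of 2,4,6-trimethylphenyl on a sulfur. Going by the values given here, no measured pair shows a change of this kind, so the direction is uncertain; the step from compound 2 to compound 3 in this assay is expected at a 2.8-fold lower number from compound 2 to compound 3 (0.44 log units; beyond the scatter), leaning toward a lower number. For compound 3 the estimate in this assay is 12000 nM, in the range 2500 nM to 60000 nM.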

Compound 3, half-maximal inhibitory concentration: 282 nM
Compound 3: middle estimate off by 43-fold (1.63 log units), on the high side; measured number outside the range, below it.
By their numbers in this assay, from the lowest: compound 3; then compound 1; then compound 2.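

On a sulfur whose other neighbour is a saturated chain carbon, the aryl group strongly sets the read-out in this assay: 2-iodophenyl in place of 2,4,6-trimethylphenyl gives a 120-fold lower number from compound 2 to compound 3 (2.07 log units; beyond the scatter) in this series. The larger change on an aromatic carbon, to the iodine-bearing group, gives a 22-fold lower number from compound 1 to compound 3 (1.35 log units; beyond the scatter), so this group outperforms the one with the non-aromatic ring. Nothing at hand accounts for either step.

Going by these compounds, whether the iodine or the loss of the methyl groups carries the step remains open. Plain phenyl or 2-chlorophenyl on the same sulfur would separate the two.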